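A few compounds are considered here, and "the series" means these few. Any claim that something is new, unique, unknown or untested is made for them only; others in the source may bear on it.

Measured so far in a physicochemical assay for acid dissociation, using potentiometric titration:
compound 1 `CC(=O)/C(C)=N/OCc1cc(=O)oc2ccc(Cl)cc12`, 5.4
compound 2 `CC(=O)/C(C)=N/OCc1cc(=O)oc2cc(C)ccc12`, 5.5
compound 3 `CC(=O)/C(C)=N/OCc1cc(=O)oc2cc(C)cc(C)c12`, 5.5

All three values lie within the usual scatter of one another; compound 2 stands level with compound 3, and compound 1 is within scatter of both. For the measured compounds named here, the single measured step, no change at the digits printed from compound 2 to compound 3 (within the scatter), shows that adding a methyl to an aromatic carbon leaves this assay unchanged.

Compound 4 `CC(=O)/C(C)=N/OCc1cc(=O)oc2cc(Cl)ccc12` is not yet measured. It differs from compound 2 as follows: chloro in place of methyl on an aromatic carbon. Going by the values given here, no measured step covers chloro in place of methyl directly. The only related data are the unchanged step from compound 2 to compound 3 and the value of compound 1, which carries a chloro elsewhere and gives 5.4, within scatter of compound 2. On that basis the step from compound 2 to compound 4 is expected to be small, a number 0.10 log units lower from compound 2 to compound 4 (within the scatter), at most a slight lowering, not clearly beyond scatter. Compound 4 is therefore estimated at 5.4, in the range 5.2 to 5.6.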

Compound 4, acid dissociation constant: 5.4
Compound 4: middle estimate and measured number agree at the digits printed; the measured number falls inside the stated range.
By their numbers in this assay, from the lowest: compounds 1, 4, 2 and 3 (each within the scatter of the next).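

In this assay, for the compounds shown here, the step of a number 0.10 log units lower from compound 2 to compound 4 (within the scatter) is the first direct reading of chloro in place of methyl on this aromatic carbon, meta to a fused ring and para to a fused ring. Both groups at this position give numbers within the scatter of each other, so this exchange does not separate them in this read-out. Nothing at hand bears on why the step is so small.

Going by these compounds, whether an amine or a carboxylic acid on this aromatic carbon would also stay within the scatter of compound 2 remains open.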